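The source may hold more compounds than are shown below. What is called first, only, known or untested is meant among the compounds shown, and "the series" means these compounds.

Compound 1 `O=C(/C=C/c1ccc([N+](=O)[O-])o1)c1ccc(N2CCCCC2)cc1` and compound 2 `O=C(/C=C/c1ccc([N+](=O)[O-])o1)c1ccc(N2CCNCC2)cc1` share the same core. In an ADME assay on Vero cells (Chlorocebus sabaeus) for cytotoxicity, read by resazurin assay, with a stated time of 72 h (on this read-out higher numbers stand for lower toxicity in this test and lower numbers for higher toxicity in this test), compound 1 gives 349000 nM. In this assay compound 2 gives only a limit, > 100000 nM, not a number. The step from compound 1 to compound 2, a step that the limit leaves unreadable from compound 1 to compound 2, cannot be sized because of the limit of > 100000 nM in this assay, at which 1 of the 2 values shown sits. Compound 3 `O=C(/C=C/c1ccc([N+](=O)[O-])o1)c1ccc(Br)cc1` differs from compound 2 by bromo in place of piperazin-1-yl on an aromatic carbon. Within the data shown here, no measured step involves a bromo group, and the one measured step is unreadable, so the expected step that the limit leaves unreadable from compound 2 to compound 3 for compound 3 rests on little more than the value of compound 1. Compound 3 is expected to give about 120000 nM, within a range from 30000 nM to 400000 nM.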

Compound 3, half-maximal cytotoxic concentration: > 100000 nM
Compound 3 ended at the assay's limit (the forecaster's own chance of this, stated with the estimate: 35%); the middle value is on the limit's open side.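

Among these compounds, no step between compound 1, compound 2 and compound 3 can be read, because compound 2 and compound 3 each give only a limit: the limit of > 100000 nM in this assay, at which 2 of the 3 values shown sit. On these data alone, how far compound 2 and compound 3 truly lie from compound 1 in this assay stays open.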